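The source may hold more compounds than are shown below. What is called first, only, known or untested is meant among the compounds shown, and "the series" means these compounds.

Measured compounds:
Compound 1 `CC(C)(C)OC(=O)N1CCN(C(=S)SCc2cn(Cc3ccc(Cl)cc3)nn2)CC1` gives > 128000 nM in a functional assay on PC-3 cells (Homo sapiens) for inhibition, read by MTT assay, with a stated time of 72 h (on this read-out higher numbers stand for weaker inhibition and lower numbers for stronger inhibition), which is a limit of the assay and not a number.
Compound 2 `COc1cc(Cn2cc(CSC(=S)N3CCNCC3)nn2)cc(OC)c1OC` gives > 128000 nM in this assay, again a limit.
Compound 3 `S=C(SCc1cn(Cc2ccccc2Cl)nn1)N1CCNCC1` gives "not determined" (no result reported) in this assay, so no result is reported for it.

Compound 1 therefore stands at the edge of what this assay can report: two of the three compounds shown sit at the limit of > 128000 nM in this assay, at which 2 of the 3 values shown sit, and the third carries no value at all. No step between measured compounds can be read from these numbers, so nothing shown tells how any change around the shared core moves the read-out.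

Compound 4 `COc1ccc(Cn2cc(CSC(=S)N3CCN(C(=O)OC(C)(C)C)CC3)nn2)cc1` is the compound to be measured. It differs from compound 1 in one place: methoxy in place of chloro on an aromatic carbon. The swap leaves the rest of the shared core of compound 1 untouched. With compound 1 at a limit, the expected step that the limit leaves unreadable from compound 1 to compound 4 is none beyond the scatter, in no clear direction. Compound 4 is expected to give about 150000 nM, within 40000 nM to 600000 nM, most probably again reported only as a limit.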

Compound 4, half-maximal inhibitory concentration: > 128000 nM
Compound 4: only a limit was reported (the forecaster's own chance of this, stated with the estimate: 75%); the middle value is on the limit's open side.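

Going by these compounds alone, compound 1 and compound 4 both end at a limit in this assay, so the swap of chloro for methoxy gives no step that can be read: the limit of > 128000 nM in this assay, at which 3 of the 4 values shown sit. The compounds shown leave open whether any change around the shared core gives a measurable value.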